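Swapping the Phenoxy Ring: From Methyl to Fluorine

The source may report more compounds than this note shows. Statements on the series, on what has been measured and on what is new or still open speak of the compounds shown alone.

Measured compounds:
Compound 1 `Cc1cccc(C)c1Oc1nc(Nc2ccc(C#N)cc2)nc2ccccc12` gives 35000 nM
Compound 2 `N#Cc1ccc(Nc2nc(Oc3ccc(Br)cc3)c3ccccc3n2)cc1` gives 215000 nM
Compound 3 `Cc1ccccc1Oc1nc(Nc2ccc(C#N)cc2)nc2ccccc12` gives 355000 nM

All three share one core and differ only in the ring carried on the oxygen. They were tested in an ADME assay on MT4 cells (Homo sapiens) for cytotoxicity, read by MTT assay, with a stated time of 4 days; on this read-out lower numbers stand for higher toxicity in this test and higher numbers for lower toxicity in this test. Compound 3 holds the highest of the three numbers. Its nearest neighbour is compound 2, and the step of a 1.7-fold higher number from compound 2 to compound 3 (0.22 log units; within the scatter) lies within the scatter, so these two cannot be ranked. The steps of a 10-fold higher number from compound 1 to compound 3 (1.01 log units; beyond the scatter) and a 6.1-fold higher number from compound 1 to compound 2 (0.79 log units; beyond the scatter) are beyond the scatter, marking compound 1 as the most toxic of the three in this test.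

Compound 4 `N#Cc1ccc(Nc2nc(Oc3ccc(F)cc3)c3ccccc3n2)cc1` has not been measured. The change from compound 3 is 4-fluorophenyl in place of 2-methylphenyl on an oxygen on an aromatic ring. Within the data shown here, the step that bears most directly on it is the one from compound 2 to compound 3, which exchanged 4-bromophenyl for 2-methylphenyl and stayed within the scatter. Among the measured compounds shown here, compound 4 carries 4-fluorophenyl, and nothing among the measured compounds points to a shift beyond the scatter. Compound 4 is therefore expected to show a 1.4-fold lower number from compound 3 to compound 4 (0.15 log units; within the scatter), a step within the scatter. For compound 4 the estimate is 250000 nM, with a range from 80000 nM to 600000 nM.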

Compound 4, half-maximal cytotoxic concentration: > 351000 nM
Compound 4: only a limit was reported; the forecaster's own chance of this, stated with the estimate: 15%; middle value at least 1.4-fold (0.14 log units) away from the limit.
By their numbers in this assay, from the lowest: compound 1; then compounds 2 and 3 (each within the scatter of the next).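

In this assay, compound 4 is reported only as a limit: the limit of > 351000 nM in this assay, at which 1 of the 4 values shown sits. Fluoro in place of bromo gives an at least 1.6-fold higher number from compound 2 to compound 4 (0.21 log units; that floor lies within the scatter), a floor that does not separate the two compounds, and the step from compound 3 to compound 4 cannot be read. The comparison with the 2,6-dimethylphenyl ring gives an at least 10-fold higher number from compound 1 to compound 4 (1.00 log units; beyond the scatter), so 4-fluorophenyl joins 4-bromophenyl and 2-methylphenyl in standing clear of compound 1, which is now the most toxic of the four in this test.

From the compounds shown here alone, how far compound 4 really lies from compound 2 and compound 3 remains open, since its position is bounded on one side only. Also open, going by these compounds, is how a phenyl ring on the oxygen would read in this test if it carried a methoxy group or an amine instead.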